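Swapping an anilide for a dioxopiperidine amide on a thiophene core

The source may hold more compounds than are shown below. What is called first, only, known or untested is meant among the compounds shown, and "the series" means these compounds.

Measured so far:
- compound 1, `Nc1sc(-c2ccc(Cl)cc2)c(-c2ccc(Cl)cc2)c1C(=O)Nc1ccccc1`: 25000 nM
- compound 2, `CCOC(=O)Nc1sc(-c2ccc(Cl)cc2)c(-c2ccc(Cl)cc2)c1C(=O)NC1CC1`: 39800 nM

In a functional assay on A549 cells (Homo sapiens) for inhibition, read by sulforhodamine B assay, with a stated time of 72 h (on this read-out lower numbers stand for stronger inhibition and higher numbers for weaker inhibition), compound 1 gives 25000 nM. Compound 2 gives 39800 nM in this assay. Compound 1 carries the lowest of the two numbers, but the gap to compound 2 lies within the usual scatter of repeated measurements, so the two cannot be told apart on these data.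

The next compound, compound 3, has the structure `Nc1sc(-c2ccc(Cl)cc2)c(-c2ccc(Cl)cc2)c1C(=O)N1CCC(=O)CC1=O`. It keeps the shared core of compound 1 and changes only the amide partner: 2,4-dioxopiperidin-1-yl in place of anilino on a carbonyl carbon. Going by the values given here, no measured pair here shows how such a change plays out, so there is nothing to lean on beyond the two weak numbers of compound 1 and compound 2.

Given that, the expected step from compound 1 to compound 3 in this assay is a 1.2-fold higher number from compound 1 to compound 3 (0.08 log units; within the scatter), meaning no clear move beyond the scatter in either direction. Compound 3 is expected to give about 30000 nM in this assay, within a range of 8000 nM to 100000 nM.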

Compound 3, half-maximal inhibitory concentration: 4090 nM
For compound 3 the middle estimate is 7.3-fold (0.87 log units) above the measured one, and the stated range ends above it.
By their numbers in this assay, from the lowest: compound 3; then compounds 1 and 2 (each within the scatter of the next).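

On the carbonyl carbon of the shared core, the amide partner turns out to matter in this assay: 2,4-dioxopiperidin-1-yl in place of anilino gives a 6.1-fold lower number from compound 1 to compound 3 (0.79 log units; beyond the scatter), a modest step but one beyond the scatter, and the first clear difference in this set, as compound 1 and compound 2 could not be told apart. The change is a bundle, though: an aromatic ring of carbon only and the hydrogen-bond donor of the anilino group leave, while a non-aromatic ring with hydrogen-bond acceptors enters, so this one step cannot show which of these differences goes with the lower number. Nothing measured here explains the move, and the step stands only as an observation.

Going by these compounds, it stays open whether the two ring carbonyls are needed at all, which a plain piperidin-1-yl group or a morpholin-4-yl group on the same carbonyl carbon could help to settle. On these data alone, it is also open whether the step would carry over to a core bearing something other than the free amine of compound 1, or to other cell lines.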